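A smaller aryl group on the shared core: compound 4

The source may report more compounds than this note shows. Statements on the series, on what has been measured and on what is new or still open speak of the compounds shown alone.

Compound 1, `O=C(NCCCCc1ccccc1)c1cccc(C2SCC(=O)N2c2cccc(-c3c[nH]nn3)c2)c1`, gives 951 mL.min-1.g-1 in an ADME assay on microsomes from liver (Mus musculus) for metabolic stability, read by LC-MS, using NADPH, with a stated time of 10 min, tested at 0.1 uM; on this read-out lower numbers stand for slow clearance and higher numbers for fast clearance.
Compound 2, `C#Cc1cccc(N2C(=O)CSC2c2cccc(C(=O)NCCCCc3ccccc3)c2)c1`, gives 1900 mL.min-1.g-1 in this assay.
Compound 3, `COc1ccc(F)cc1N1C(=O)CSC1c1cccc(C(=O)NCCCCc2ccccc2)c1`, gives 2250 mL.min-1.g-1 in this assay.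

All three compounds are cleared quickly in this assay. Compound 3 sits at the fast end of the three numbers: the step of a 2.4-fold higher number from compound 1 to compound 3 (0.37 log units; beyond the scatter) is beyond the scatter, whereas the step of a 1.2-fold higher number from compound 2 to compound 3 (0.07 log units; within the scatter) is within it, so compound 2 and compound 3 cannot be told apart. The step of a 2.0-fold higher number from compound 1 to compound 2 (0.30 log units; within the scatter) is also within the scatter.

Compound 4, `O=C(NCCCCc1ccccc1)c1cccc(C2SCC(=O)N2c2ccccc2F)c1`, has not yet been measured. It differs from compound 3 in one place: 2-fluorophenyl in place of 5-fluoro-2-methoxyphenyl on an amide-type nitrogen in a ring. Among the measured compounds shown here, no measured step swaps one six-membered carbon ring for another of the same kind on this amide-type nitrogen. The nearest guide is the step of a 1.2-fold higher number from compound 2 to compound 3 (0.07 log units; within the scatter), where two different aryl groups on that nitrogen gave numbers within the scatter of each other, and even the larger change in a 2.4-fold higher number from compound 1 to compound 3 (0.37 log units; beyond the scatter) was only modest. A step no larger than the scatter is therefore expected, in no particular direction.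

Compound 4 is therefore estimated at 2000 mL.min-1.g-1, with a range of 1000 mL.min-1.g-1 to 4000 mL.min-1.g-1, which means an expected step of a 1.1-fold lower number from compound 3 to compound 4 (0.05 log units; within the scatter).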

Compound 4, intrinsic clearance in microsomes: 2010 mL.min-1.g-1
The estimate for compound 4 lay 1.0-fold (0.00 log units) below the measured number; measured number inside the range.
By their numbers in this assay, from the lowest: compounds 1, 2, 4 and 3 (each within the scatter of the next, the first and the last beyond it).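

Taking the methoxy group away, so that 2-fluorophenyl stands in place of 5-fluoro-2-methoxyphenyl and the counted hydrogen-bond acceptor is gone, leaves clearance unresolved in this assay at a 1.1-fold lower number from compound 3 to compound 4 (0.05 log units; within the scatter) and shows that this smaller aryl group on the amide-type nitrogen gives no measurable gain in stability. Compound 4 also cannot be told apart from the ethynyl compound, with a 1.1-fold higher number from compound 2 to compound 4 (0.02 log units; within the scatter) as the step, so three different aryl groups at this position now sit together at the fast end of the scale, while the triazole-bearing compound is separated from compound 4 only modestly by a 2.1-fold higher number from compound 1 to compound 4 (0.33 log units; beyond the scatter) and lies within the scatter of compound 2. Nothing shown gives a cause for these numbers.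

Still open, from the compounds shown here alone, is whether any group on this nitrogen can bring clearance down substantially, for example an aryl ring carrying an amine or a carboxylic acid. Going by these compounds, all four compounds also share the same long chain on the amide of the core, so what a shorter chain there would do to clearance remains unknown.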